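The source may hold more compounds than are shown below. What is called first, only, known or untested is meant among the compounds shown, and "the series" means these compounds.

Three measured compounds share one core and differ only in the chain that hangs from it. Compound 1 `N#CCCCc1c[nH]c2ccc(F)cc12` gives 63 nM in an assay on isolated protein (urine) for inhibition of Myeloperoxidase (Homo sapiens), with a stated time of 5 min (a higher number here means a weaker inhibitor, a lower number a stronger inhibitor), compound 2 `NC(=O)CCCCc1c[nH]c2ccc(F)cc12` gives 39 nM in this assay, and compound 3 `NCC(N)CCc1c[nH]c2ccc(F)cc12` gives 60 nM in this assay. Every step among them stays within the scatter: a 1.6-fold lower number from compound 1 to compound 2 (0.21 log units; within the scatter), a 1.1-fold lower number from compound 1 to compound 3 (0.02 log units; within the scatter), and a 1.5-fold higher number from compound 2 to compound 3 (0.19 log units; within the scatter). Compound 3 thus stands as the second highest of the three numbers, closest to compound 1 and furthest from compound 2, with neither gap beyond the scatter.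

Compound 4 `N#CSCCCc1c[nH]c2ccc(F)cc12` is not yet measured. Its difference from compound 3 is (cyanosulfanyl)methyl in place of 1,2-diaminoethyl on a saturated chain carbon, two bonds along the chain from an aromatic carbon. Within the data shown here, the steps that bear on this are those in which the chain end was exchanged, above all the change from compound 1 to compound 3 and that from compound 2 to compound 3, both within the scatter; compound 4 carries a nitrile at the chain end as compound 1 does, and compound 1 and compound 3 show nearly the same number. On that basis the expected step is no change at the digits printed from compound 3 to compound 4 (within the scatter), that is, no movement beyond the scatter in this assay. Compound 4 is therefore estimated at 60 nM in this assay, with a range from 25 nM to 150 nM.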

Compound 4, half-maximal inhibitory concentration: 5 nM
Compound 4: middle estimate off by 12-fold (1.08 log units), on the high side; the measured number lies below the stated range.
By their numbers in this assay, from the lowest: compound 4; then compounds 2, 3 and 1 (each within the scatter of the next).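

Every earlier exchange of the chain end stayed within the scatter in this assay, but this position now proves able to move the number: cyanosulfanyl in place of cyano on a saturated chain carbon, three bonds along the chain from an aromatic carbon, gives a 13-fold lower number from compound 1 to compound 4 (1.10 log units; beyond the scatter). The outcome does not hang on which earlier chain is taken as the starting point, as the other two comparisons show a 7.8-fold lower number from compound 2 to compound 4 (0.89 log units; beyond the scatter) and a 12-fold lower number from compound 3 to compound 4 (1.08 log units; beyond the scatter). Compound 1 also ends in a nitrile, so a nitrile at the chain end is not enough on its own for this number, and nothing at hand gives a reason for the gain.

The compounds shown leave open whether the sulfur or the nitrile attached to it carries the result, a question that a methylsulfanyl end, or a plain nitrile chain with a methylene where the sulfur stands, would address. Also open, on these data alone, is whether the cyanosulfanyl end keeps its number on a shorter or longer chain, or with hydrogen in place of the fluorine on the shared core.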